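The source may hold more compounds than are shown below. What is called first, only, known or untested is meant among the compounds shown, and "the series" means these compounds.

In a functional assay on MDA-MB-231 cells (Homo sapiens) for antiproliferative activity, read by MTT assay, with a stated time of 24 h (on this read-out lower numbers stand for stronger inhibition and higher numbers for weaker inhibition), compound 1 `O=C(NNc1ccccc1F)c1ccc(NS(=O)(=O)c2cnc(O)nc2O)cc1` gives > 20000 nM, which is a limit of the assay and not a number. Compound 2 `Cc1ccccc1NNC(=O)c1cccc(NS(=O)(=O)c2cnc(O)nc2O)c1` also gives only a limit, > 20000 nM. Compound 3 `Cc1cccc(NNC(=O)c2cccc(NS(=O)(=O)c3cnc(O)nc3O)c2)c1` likewise stands at a limit, > 20000 nM. Taken together, the evidence so far is the limit of > 20000 nM in this assay, at which 3 of the 3 values shown sit. Compound 4 `O=C(NNc1ccccc1Cl)c1cccc(NS(=O)(=O)c2cnc(O)nc2O)c1` carries 2-chlorophenyl in place of 3-methylphenyl on an amine nitrogen. Among the measured compounds shown here, the one measured step that changes this group is a step that the two limits leave unreadable from compound 2 to compound 3, and it offers no size to carry forward. No step beyond the usual scatter is therefore expected, and the estimated step is a step that the limit leaves unreadable from compound 3 to compound 4. The expected value for compound 4 is 25000 nM, with an estimated range from 12000 nM to 50000 nM.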

Compound 4, half-maximal inhibitory concentration: 2090 nM
Compound 4: middle estimate off by 12-fold (1.08 log units), on the high side, outside the stated range (below it).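

In this assay, the group on the amine nitrogen now proves able to move the read-out: chloro in place of methyl on an aromatic carbon, with nothing else changed, gives an at least 9.5-fold lower number from compound 2 to compound 4 (0.98 log units; beyond the scatter). Replacing 3-methylphenyl with 2-chlorophenyl likewise gives an at least 9.5-fold lower number from compound 3 to compound 4 (0.98 log units; beyond the scatter). Compound 4 is thus the only compound shown that yields a real number rather than a limit: the limit of > 20000 nM in this assay, at which 3 of the 4 values shown sit.

On these data alone, both steps start from a limit, so their full size stays open. As far as these compounds go, how 2-bromophenyl, 2-methoxyphenyl or 3-chlorophenyl would read at this place also remains open.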